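From trifluorophenyl to chlorophenyl at the assay limit

The source may hold more compounds than are shown below. What is called first, only, known or untested is meant among the compounds shown, and "the series" means these compounds.

Values from a functional assay on SEM cells (Homo sapiens) for cytotoxicity, with a stated time of 72 h (on this read-out higher numbers stand for an effect only at larger amounts of compound and lower numbers for an effect already at smaller amounts), follow
- Compound 1 `C=C[C@@](C)(/C=C/c1ccc(OCc2ccccc2)cc1)CCC=C(C)C` gives > 36600 nM as a limit
- Compound 2 `C=C[C@@](C)(/C=C/c1ccc(Nc2ccc(Cl)c(F)c2)cc1)CCC=C(C)C` gives > 36600 nM as a limit
- Compound 3 `C=C[C@@](C)(/C=C/c1ccc(Nc2cc(F)c(F)cc2F)cc1)CCC=C(C)C` gives > 36600 nM as a limit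

Compound 3 stands at the limit of > 36600 nM in this assay, at which 3 of the 3 values shown sit, and that is a limit, not a number. Compound 4 `C=C[C@@](C)(/C=C/c1ccc(Nc2ccc(Cl)cc2)cc1)CCC=C(C)C` brings one structural change, 4-chlorophenyl in place of 2,4,5-trifluorophenyl on a nitrogen on an aromatic ring and the rest of the molecule stays the same. Going by the values given here, two measured steps bear on it, a step that the two limits leave unreadable from compound 1 to compound 2 and a step that the two limits leave unreadable from compound 2 to compound 3 and neither has a size that can be read. No step beyond the usual scatter is therefore expected in this assay and no direction can be given. The expected size is a step that the limit leaves unreadable from compound 3 to compound 4 and it remains only an estimate. Compound 4 is expected near 40000 nM with an estimated range from 15000 nM to 80000 nM. Compound 4 may well give a limit too.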

Compound 4, half-maximal effective concentration: > 36600 nM
Compound 4: no number, only a limit (the forecaster's own chance of this, stated with the estimate: 75%); the middle value lies beyond the limit too.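

Compound 4 gives only a limit, not a number, so its steps from compound 1, compound 2 and compound 3 cannot be read: the limit of > 36600 nM in this assay, at which 4 of the 4 values shown sit. The compounds shown leave open whether any of these group changes alters the effect at all.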